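From piperidin-1-yl to 4-methoxypiperidin-1-yl

The source may hold more compounds than are shown below. What is called first, only, known or untested is meant among the compounds shown, and "the series" means these compounds.

In an ADME assay on S9 fraction from liver (Rattus norvegicus, strain Wistar) for metabolic stability, tested at 0.1 uM (a lower number here means slower removal, a higher number faster removal of the compound), compound 1 `CN(C)c1cc(OCc2cc(F)c(Oc3ccc(Cl)c(C(F)(F)F)c3)c(F)c2)nc(=O)n1C` gives 82.8 mL/min/kg and compound 2 `Cn1c(N2CCCC2)cc(OCc2cc(F)c(Oc3ccc(Cl)c(C(F)(F)F)c3)c(F)c2)nc1=O` gives 3.11 mL/min/kg while compound 3 `Cn1c(N2CCCCC2)cc(OCc2cc(F)c(Oc3ccc(Cl)c(C(F)(F)F)c3)c(F)c2)nc1=O` gives 21.8 mL/min/kg as the second highest of the three numbers. Compound 4 `COC1CCN(c2cc(OCc3cc(F)c(Oc4ccc(Cl)c(C(F)(F)F)c4)c(F)c3)nc(=O)n2C)CC1` differs from compound 3 by methoxy in place of hydrogen on a saturated ring carbon three ring bonds from the ring nitrogen. Within the data shown here, three measured steps bear on this change only indirectly, as each replaces the whole amine. Dimethylamino to piperidin-1-yl is modest (a 3.8-fold lower number from compound 1 to compound 3 (0.58 log units; beyond the scatter)), dimethylamino to pyrrolidin-1-yl is large (a 27-fold lower number from compound 1 to compound 2 (1.43 log units; beyond the scatter)), and pyrrolidin-1-yl to piperidin-1-yl is modest (a 7.0-fold higher number from compound 2 to compound 3 (0.85 log units; beyond the scatter)). None of them places a group on a saturated ring carbon, so they give no direction for this change. They do argue for a wide range. A step within the scatter is therefore expected, and the estimated step is small (a 1.1-fold higher number from compound 3 to compound 4 (0.06 log units; within the scatter)). For compound 4 the expected value is 25 mL/min/kg within an estimated range of 8 mL/min/kg to 75 mL/min/kg for now.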

Compound 4, clearance: 184 mL/min/kg
Compound 4: the middle estimate sits 7.4-fold (0.87 log units) below what was measured, outside the stated range (above it).
By their numbers in this assay, from the lowest: compound 2; then compound 3; then compound 1; then compound 4.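

In this assay, among these compounds, methoxy in place of hydrogen on a saturated ring carbon, three ring bonds from the ring nitrogen, is the first change made on the amine ring itself, and it gives an 8.4-fold higher number from compound 3 to compound 4 (0.93 log units; beyond the scatter) and so moves the number well beyond the scatter. This single substitution more than cancels the drop seen on replacing dimethylamino with piperidin-1-yl, since 4-methoxypiperidin-1-yl gives a 2.2-fold higher number from compound 1 to compound 4 (0.35 log units; beyond the scatter) and places compound 4 highest of the four. Against the pyrrolidin-1-yl amine, the 4-methoxypiperidin-1-yl group gives a 59-fold higher number from compound 2 to compound 4 (1.77 log units; beyond the scatter) and this is the widest step in the set.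

Going by these compounds, whether hydroxy or fluoro on the same ring carbon would raise the number as methoxy does remains open, as does the effect of methoxy on the pyrrolidin-1-yl ring. Nothing in the data at hand gives a cause for this rise.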